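This account rests on a few compounds, and the source may have more. Where it says the series, first, only, none or still open, it means among the compounds named here.

Measured compounds:
- compound 1 `CCCCCCCCc1ccc(OCC(=O)Cn2nnnc2C)cc1`: 41 nM
- compound 2 `CCCCCCCCc1ccc(OCC(=O)Cn2nnnc2-c2ccc(S(=O)(=O)N(C)C)cc2)cc1`: 1400 nM
- compound 3 `CCCCCCCCc1ccc(OCC(=O)Cn2nnnc2-c2cccc(S(=O)(=O)N(C)C)c2)cc1`: 1900 nM

Among these three, compound 3 has the highest number in an assay on microsomes from brain for inhibition of Fatty-acid amide hydrolase 1 (Rattus norvegicus), read by fluorescence and HPLC, with a stated time of 60 min; a higher number here means a weaker inhibitor, a lower number a stronger inhibitor; compound 2 stands nearest, with a 1.4-fold higher number from compound 2 to compound 3 (0.13 log units; within the scatter), and compound 1 stands furthest, with a 46-fold higher number from compound 1 to compound 3 (1.67 log units; beyond the scatter).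

Compound 4 `CCCCCCCCc1ccc(OCC(=O)Cn2nnnc2-c2ccncc2)cc1` has not been measured. The change from compound 3 is pyridin-4-yl in place of 3-(dimethylsulfamoyl)phenyl on an aromatic carbon. Within the data shown here, no measured step replaces one aryl group with another of a different kind; the steps that bear on it are those that exchanged methyl for an aryl group, namely a 34-fold higher number from compound 1 to compound 2 (1.53 log units; beyond the scatter) and a 46-fold higher number from compound 1 to compound 3 (1.67 log units; beyond the scatter), both large, while the move of the dimethylsulfamoyl group, a 1.4-fold higher number from compound 2 to compound 3 (0.13 log units; within the scatter), was within the scatter. Compound 4 keeps an aryl group but loses the dimethylsulfamoyl substituent, so it is expected to land between compound 1 and compound 3 in this assay, closer to compound 3. Compound 4 is estimated at 500 nM, with a range of 120 nM to 2500 nM, which is expected to mean a 3.8-fold lower number from compound 3 to compound 4 (0.58 log units; beyond the scatter).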

Compound 4, half-maximal inhibitory concentration: 190 nM
For compound 4 the middle estimate is 2.6-fold (0.42 log units) above the measured one; the measured number falls inside the stated range.
By their numbers in this assay, from the lowest: compound 1; then compound 4; then compounds 2 and 3 (each within the scatter of the next).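

In this assay, an aryl group on this aromatic carbon of the five-membered ring does not have to cost as much as the two dimethylsulfamoyl-bearing compounds suggested, for pyridin-4-yl gives a 10-fold lower number from compound 3 to compound 4 (1.00 log units; beyond the scatter) and a 7.4-fold lower number from compound 2 to compound 4 (0.87 log units; beyond the scatter). Methyl still holds the lowest number, with a 4.6-fold higher number from compound 1 to compound 4 (0.67 log units; beyond the scatter), so all three aryl groups shown raise the number over methyl, but by an amount that depends on the aryl group. Nothing measured here accounts for the difference between these aryl groups.

The compounds shown do not separate the loss of the dimethylsulfamoyl group from the arrival of the ring nitrogen, a question that plain phenyl would address. Going by these compounds, whether pyridin-3-yl, or a short chain such as ethyl, would come closer to methyl also stays open.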